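From Methyl to Trifluoromethyl: A Step Not Yet Measured

The source may hold more compounds than are shown below. What is called first, only, known or untested is meant among the compounds shown, and "the series" means these compounds.

- compound 1 `COc1ccc(-c2[nH]c3ccc(C)cc3c2C=O)cc1` measured at 86 nM
- compound 2 `Cc1ccc(-c2[nH]c3ccc(C)cc3c2C=O)cc1` measured at 48 nM
- compound 3 `CCCCc1ccc2[nH]c(-c3ccc(C)cc3)c(C=O)c2c1` measured at 34 nM
- compound 4 `CCCCc1ccc2[nH]c(-c3ccc(C(F)(F)F)cc3)c(C=O)c2c1` still without a number

All three numbers come from a functional assay on MDA-MB-231 cells (Homo sapiens) for antiproliferative activity, with a stated time of 4 days (a higher number here means a weaker inhibitor, a lower number a stronger inhibitor), and the compounds share one core. Compound 3 at 34 nM sits within the scatter of compound 2 at 48 nM and clearly under compound 1 at 86 nM on this scale.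

Compound 4 arises from compound 3 by trifluoromethyl in place of methyl on an aromatic carbon and nothing else changes. The closest guide is the swap at that same carbon, methyl in place of methoxy, which gave a 1.8-fold lower number from compound 1 to compound 2 (0.25 log units; within the scatter) in this series. Propyl in place of hydrogen on a saturated chain carbon, a change elsewhere in the molecule, gave a 1.4-fold lower number from compound 2 to compound 3 (0.15 log units; within the scatter) in turn. Going by these compounds, neither measured step involves trifluoromethyl, so the direction remains open. No step beyond the scatter is expected, and the estimated outcome is a 1.3-fold higher number from compound 3 to compound 4 (0.12 log units; within the scatter) for this swap. Compound 4 is estimated at 45 nM with an expected range from 18 nM to 120 nM for now.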

Compound 4, half-maximal inhibitory concentration: 33 nM
Estimate against measurement, compound 4: 1.4-fold (0.13 log units) above; low and high end bracket the measured number.
By their numbers in this assay, from the lowest: compounds 4, 3, 2 and 1 (each within the scatter of the next, the first and the last beyond it).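

In this assay, trifluoromethyl in place of methyl on this aromatic carbon, para to a large group, gave a 1.0-fold lower number from compound 3 to compound 4 (0.01 log units; within the scatter), a step within the scatter. For the compounds shown here, until now this carbon had been seen only in the swap from methoxy to methyl, so this result adds a third group there: with three fluorine atoms brought in, the number holds within the scatter of compound 3. Nothing measured here bears on why the swap leaves the number where it is.

What the compounds shown leave open is how this carbon responds to a group of a different kind, such as an amine, a carboxylic acid or a longer chain, in place of the methyl of compound 3. Going by these compounds, whether the same swap reads alike in other cell types also stays open.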